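This account rests on a few compounds, and the source may have more. Where it says the series, first, only, none or still open, it means among the compounds named here.

In a functional assay on MCF7 cells (Homo sapiens) for antiproliferative activity, read by sulforhodamine B assay, with a stated time of 48 h (on this read-out higher numbers stand for weaker inhibition and lower numbers for stronger inhibition), compound 1 `COc1cccc(C2=NN(c3ccccc3)C(c3ccc(Br)cc3)C2O)c1` gives 11 nM and compound 2 `COc1ccc(C2=NN(c3ccccc3)C(c3ccc(OC)cc3)C2O)cc1` gives 19 nM. These two values lie within the usual scatter of each other, so they cannot be ranked, and compound 1 simply sits with compound 2 in the low nanomolar range. Compound 3 `COc1cccc(C2=NNC(c3ccc(Br)cc3)C2O)c1` differs from compound 1 at one place: hydrogen in place of phenyl on an amine nitrogen in a ring. In words, this is hydrogen in place of phenyl on an amine nitrogen in a ring. Among the compounds with values here, both measured compounds carry that phenyl, so no measurement yet shows what happens without it. The estimate therefore starts from compound 1 at 11 nM and is uncertain. Removing a whole phenyl is expected to give a large step towards weaker inhibition, beyond the scatter, and the estimated size is a 27-fold higher number from compound 1 to compound 3 (1.44 log units; beyond the scatter). For compound 3, the estimated value in this assay is 300 nM, with an expected range of 40 nM to 2500 nM.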

Compound 3, half-maximal inhibitory concentration: 49 nM
Compound 3: the middle estimate sits 6.1-fold (0.79 log units) above what was measured; low and high end bracket the measured number.
By their numbers in this assay, from the lowest: compounds 1 and 2 (each within the scatter of the next); then compound 3.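

In this assay, the phenyl on the amine nitrogen in a ring counts for something, but it is not essential. Replacing it with hydrogen gives a 4.5-fold higher number from compound 1 to compound 3 (0.65 log units; beyond the scatter), a modest step that still lies beyond the scatter, and compound 3 at 49 nM keeps its inhibition in the nanomolar range with no carbon group on this nitrogen at all. Nothing measured here gives a reason for this step.

Going by these compounds, only phenyl and hydrogen are seen at this nitrogen, so it remains open how a methyl, a benzyl or an acetyl group would fall relative to these two. Also open, on these data alone, is whether the same swap would bring a step of similar size in compound 2, which carries different groups on the shared core.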